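This account rests on a few compounds, and the source may have more. Where it says the series, first, only, none or still open, it means among the compounds named here.

Working notes on the series. In a functional assay on HepG2 cells (Homo sapiens) for antiproliferative activity, read by MTT assay, with a stated time of 24 h (a lower number here means a stronger inhibitor, a higher number a weaker inhibitor), compound 1 `c1ccc(CSc2nnc(-c3ccc4c(c3)OCCO4)n2-c2ccccc2)cc1` gives 5960 nM, compound 2 `Clc1cccc(CSc2nnc(-c3ccc4c(c3)OCCO4)n2-c2ccccc2)c1` gives 2390 nM and compound 3 `Cc1ccc(CSc2nnc(-c3ccc4c(c3)OCCO4)n2-c2ccccc2)cc1` gives 56800 nM. Compound 2 has the lowest number of the three and is the strongest inhibitor so far, with both gaps beyond the scatter.

The next member is compound 4 `Fc1ccc(CSc2nnc(-c3ccc4c(c3)OCCO4)n2-c2ccccc2)cc1`, and the change is 4-fluorophenyl in place of 3-chlorophenyl on a saturated chain carbon bound to a sulfur. Going by the values given here, no measured compound carries fluorine, so no step measures this exchange directly.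

Among the compounds with values here, three steps bear on it. Chloro in place of hydrogen gave a 2.5-fold lower number from compound 1 to compound 2 (0.40 log units; beyond the scatter), and compound 4 gives up that chloro group. Methyl in place of hydrogen gave a 9.5-fold higher number from compound 1 to compound 3 (0.98 log units; beyond the scatter), which shows that a change at this ring can cost far more than the chloro group gains. The closest exchange, a 24-fold higher number from compound 2 to compound 3 (1.38 log units; beyond the scatter), also removes the 3-chlorophenyl group and is large. With only these three values, the direction is clearer than the size.

A modest rise is expected, landing near compound 1 at 5960 nM. The expected step is a 2.7-fold higher number from compound 2 to compound 4 (0.43 log units; beyond the scatter). Compound 4 is estimated at 6500 nM, with an expected range of 1800 nM to 28000 nM.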

Compound 4, half-maximal inhibitory concentration: 1020 nM
For compound 4 the middle estimate is 6.4-fold (0.80 log units) above the measured one; measured number below the stated range.
By their numbers in this assay, from the lowest: compound 4; then compound 2; then compound 1; then compound 3.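

Replacing 3-chlorophenyl with 4-fluorophenyl gives a 2.3-fold lower number from compound 2 to compound 4 (0.37 log units; beyond the scatter), which makes compound 4 the strongest inhibitor of the four in this assay, with its steps to all three others beyond the scatter. Fluoro in place of hydrogen gives a 5.8-fold lower number from compound 1 to compound 4 (0.77 log units; beyond the scatter), so a lower number at this ring does not depend on the chloro group, while fluoro in place of methyl gives a 56-fold lower number from compound 3 to compound 4 (1.75 log units; beyond the scatter), which makes the identity of the ring substituent decisive here: among these compounds, chloro and fluoro lower the number relative to compound 1, and compound 3, with methyl, goes against that direction. No measurement in hand bears on the reason for this spread across the ring substituents.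

The groups 3-chlorophenyl and 4-fluorophenyl differ in both the halogen and its place on the ring, and the compounds shown do not separate these two changes. Also open, on these data alone, is how a methoxy group, a nitrile or an amine on the ring, or a longer chain in place of the saturated chain carbon bound to a sulfur, would read in this assay.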